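Adding a second chloro to compound 1

The compounds below may be only part of what the source reports. "The series", "measured", "known", "first", "only" and "open" are said of these compounds alone.

Compound 1 `Cc1ccc(S(=O)(=O)N/C(=N\O)Nc2ccc(Cl)cc2)cc1`: 46 ug/mL
Compound 2 `O=S(=O)(N/C(=N\O)Nc1ccc(Cl)cc1)c1ccccc1`: 46 ug/mL
Compound 3 `Cc1ccc(S(=O)(=O)N/C(=N\O)Nc2ccc(Cl)c(Cl)c2)cc1`: not yet measured

In a functional assay on KB cells (Homo sapiens) for cytotoxicity (on this read-out lower numbers stand for stronger inhibition and higher numbers for weaker inhibition), compound 1 gives 46 ug/mL, and compound 2 gives 46 ug/mL, so the two stand level at the digits reported. Within the data shown here, compound 1 therefore has only one measured neighbour, and that comparison shows no separation.

The change now in question leads from compound 1 to compound 3: chloro in place of hydrogen on an aromatic carbon. A chloro takes the place of a hydrogen on an aromatic carbon, and the rest of the molecule stays as it is.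

Among the measured compounds shown here, only one measured step bears on this, no change at the digits printed from compound 1 to compound 2 (within the scatter), which lies within the scatter. That step puts hydrogen in place of methyl at another site, so it shows only that one small substitution left the read-out in this assay unmoved. For the measured compounds named here, no measured compound shows what adding a chloro does, and the data give no firm direction. The expected step is a 1.2-fold lower number from compound 1 to compound 3 (0.06 log units; within the scatter), and it is not expected to go beyond the scatter. Compound 3 is estimated at 40 ug/mL, with an expected range from 16 ug/mL to 90 ug/mL.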

Compound 3, half-maximal inhibitory concentration: 8 ug/mL
For compound 3 the middle estimate is 5.0-fold (0.70 log units) above the measured one, outside the stated range (below it).
By their numbers in this assay, from the lowest: compound 3; then compounds 1 and 2 (each within the scatter of the next).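

In this assay the step is a 5.8-fold lower number from compound 1 to compound 3 (0.76 log units; beyond the scatter) and it is the first change among the compounds shown that goes beyond the scatter. Among these compounds, the only earlier step, the swap of methyl for hydrogen that links compound 1 and compound 2, had left the read-out unmoved, so the compounds then in hand gave no sign that any single site could shift it. This carbon, ortho to a chloro group and meta to a large group, is now a place where a chloro in place of hydrogen lowers the number, though nothing measured here explains why.

Whether a bromo, a methoxy or an amine on this same carbon would lower the number as well stays open, as this one chloro is the only group shown there. Going by these compounds, it is equally open whether the same chloro added to compound 2 would give a step of like size, and whether the effect depends on the chloro group already present on that ring.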